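Adding a Second Trifluoromethyl to a Thiazole Hydrazone

A few compounds are considered here, and "the series" means these few. Any claim that something is new, unique, unknown or untested is made for them only; others in the source may bear on it.

Measured compounds:
Compound 1 `CNc1nc(C)c(C(=O)N/N=C/c2cc(C(F)(F)F)cc(C(F)(F)F)c2)s1`: > 100 ug/mL
Compound 2 `CNc1nc(C(F)(F)F)c(C(=O)N/N=C/c2cccc(C(F)(F)F)c2)s1`: > 100 ug/mL

In a functional assay on MCF7 cells (Homo sapiens) for inhibition, read by MTT assay, with a stated time of 72 h (on this read-out lower numbers stand for stronger inhibition and higher numbers for weaker inhibition), compound 1 gives only a limit, > 100 ug/mL. In this assay compound 2 likewise gives only a limit, > 100 ug/mL. Compound 2 therefore stands nowhere in particular on the numbers shown: both values sit at the limit of > 100 ug/mL in this assay, at which 2 of the 2 values shown sit, and neither compound has an actual number.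

Compound 3 `CNc1nc(C(F)(F)F)c(C(=O)N/N=C/c2cc(C(F)(F)F)cc(C(F)(F)F)c2)s1` is not yet measured. It differs from compound 2 by trifluoromethyl in place of hydrogen on an aromatic carbon. The two measured compounds share the bis-trifluoromethyl arrangement of compound 1 and the trifluoromethyl on the core of compound 2, and both sit at the limit, so nothing in the data points to compound 3 breaking away from it. No step beyond the scatter is expected in either direction. The step that this estimate means is expected to be a step that the limit leaves unreadable from compound 2 to compound 3. Compound 3 is estimated at 150 ug/mL, within 50 ug/mL to 500 ug/mL.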

Compound 3, half-maximal inhibitory concentration: > 100 ug/mL
Compound 3 ended at the assay's limit (the forecaster's own chance of this, stated with the estimate: 85%); the middle value is on the limit's open side.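

In this assay compound 3 gives > 100 ug/mL, a limit and not a number, so no step from compound 1 or compound 2 to compound 3 can be read: the limit of > 100 ug/mL in this assay, at which 3 of the 3 values shown sit.

The compounds shown leave open how far any of the three actually inhibits these cells, and whether either change to trifluoromethyl alters that.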